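The source may report more compounds than this note shows. Statements on the series, on what has been measured and on what is new or still open speak of the compounds shown alone.

Measured compounds:
- compound 1 `COc1ccc(/C=C/C(=O)c2ccc(OC)c3c2OC(C)(C)C=C3)c(F)c1` — > 10000 nM
- compound 2 `COc1ccc(C(=O)/C=C/c2ccc([N+](=O)[O-])cc2)c2c1C=CC(C)(C)O2` — 3730 nM
- compound 3 `COc1ccc(C(=O)/C=C/c2ccccc2)c2c1C=CC(C)(C)O2` — > 10000 nM

All three share one core and differ only in the aryl ring at the far end of the double-bonded chain. For the measured compounds named here, in a functional assay on HT-29 cells (Homo sapiens) for antiproliferative activity, read by MTT assay, with a stated time of 24 h (a lower number here means a stronger inhibitor, a higher number a weaker inhibitor), compound 2 gives 3730 nM, the only plain number in the set. For compound 3 the result is only a limit, > 10000 nM; it sits at the limit of > 10000 nM in this assay, at which 2 of the 3 values shown sit. For compound 1 the result is likewise a limit, > 10000 nM. Compound 3 therefore stands at the weak end of what can be read, with no number of its own.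

The new compound 4 `COc1ccc(C(=O)/C=C/c2cccs2)c2c1C=CC(C)(C)O2` is made by the change (thiophen-2-yl in place of phenyl on a double-bonded chain carbon bound to a double-bonded chain carbon). The measured steps that bear on this are an at least 2.6-fold higher number from compound 2 to compound 3 (0.42 log units; beyond the scatter) and an at least 2.6-fold lower number from compound 1 to compound 2 (0.42 log units; beyond the scatter): removing the nitro group, or swapping in the nitro-bearing ring, moves the value by a modest amount, while a step that the two limits leave unreadable from compound 1 to compound 3 cannot be read at all. Going by the values given here, no step shows a thiophen-2-yl ring, so the change from compound 3 to compound 4 rests on analogy only. Since both of the comparable rings without nitro gave only limits, little movement is expected in this assay, and the step that the limit leaves unreadable from compound 3 to compound 4 is estimated to stay within the scatter. Compound 4 is expected to give about 12000 nM, within 4000 nM to 40000 nM.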

Compound 4, half-maximal inhibitory concentration: > 10000 nM
Compound 4: no number, only a limit; the forecaster's own chance of this, stated with the estimate: 60%; the middle value is on the limit's open side.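

Swapping phenyl for thiophen-2-yl, a smaller five-membered ring that holds a sulfur atom, does not bring the series into the readable range: in this assay compound 4 gives > 10000 nM, which is a limit and not a number. Against the ring that carries the nitro group, the change to thiophen-2-yl gives an at least 2.6-fold higher number from compound 2 to compound 4 (0.42 log units; beyond the scatter), so the 4-nitrophenyl ring remains the only ring of the four shown with a plain number. The steps linking compound 1, compound 3 and compound 4 cannot be read, because all three stand at the same limit: the limit of > 10000 nM in this assay, at which 3 of the 4 values shown sit.

As far as these compounds go, whether thiophen-2-yl and phenyl differ at all in this assay stays open, as does how far the ring of compound 4 lies from the others beyond the limit. Also open is whether a plain number depends on the nitro group itself, since nothing shown tells how a phenyl ring carrying an amine or a nitrile in place of the nitro group would read, or how a thiophen-2-yl ring carrying a nitro group would.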